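This account rests on a few compounds, and the source may have more. Where it says the series, first, only, none or still open, it means among the compounds named here.

Compound 2, whose structure is `NS(=O)(=O)c1cc(-c2nnc(CNS(=O)(=O)c3ccc(Cl)cc3)o2)c(Cl)cc1SCc1ccccc1`, is one of two compounds that share a core and were tested in a functional assay on HeLa cells (Homo sapiens) for cytotoxicity, read by MTT assay, with a stated time of 72 h; a lower number here means a stronger inhibitor, a higher number a weaker inhibitor. Compound 1, with structure `NS(=O)(=O)c1cc(-c2nnc(CNC(=O)c3ccccc3)o2)c(Cl)cc1SCc1ccccc1`, gives 105000 nM. For the measured compounds named here, compound 2 gives 24000 nM, the lowest of the two numbers, and the only measured step, a 4.4-fold lower number from compound 1 to compound 2 (0.64 log units; beyond the scatter), separates them.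

Compound 3, with structure `NS(=O)(=O)c1cc(-c2nnc(/C=C/c3ccc(Br)cc3)o2)c(Cl)cc1SCc1ccccc1`, has not yet been measured. Relative to compound 2 the change is 2-(4-bromophenyl)ethenyl in place of (((4-chlorophenyl)sulfonyl)amino)methyl on an aromatic carbon, so the group that leaves carries the hydrogen-bond donor and both acceptors of that side chain, while the group that enters carries none. Going by the values given here, no measured step covers this kind of exchange. Among the compounds with values here, the one step available, a 4.4-fold lower number from compound 1 to compound 2 (0.64 log units; beyond the scatter), bears only loosely on it: it shows that replacing the group at this position can move the number by a modest amount, but in a direction that need not carry over to a chain with no donor or acceptor.

The estimate for compound 3 is therefore 20000 nM, within a wide range from 5000 nM to 80000 nM, which amounts to an expected step of a 1.2-fold lower number from compound 2 to compound 3 (0.08 log units; within the scatter).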

Compound 3, half-maximal inhibitory concentration: 29000 nM
Compound 3: the middle estimate sits 1.5-fold (0.16 log units) below what was measured, and the stated range covers the measured number.
By their numbers in this assay, from the lowest: compounds 2 and 3 (each within the scatter of the next); then compound 1.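

In this assay, the side chain at this position can be replaced wholesale with little effect on the number: exchanging the sulfonamide-bearing chain for 2-(4-bromophenyl)ethenyl gives a 1.2-fold higher number from compound 2 to compound 3 (0.08 log units; within the scatter). The group that leaves has 1 hydrogen-bond donor and 2 hydrogen-bond acceptors and the group that enters has none, so among these compounds neither is needed to reach this level of cytotoxicity. For the compounds shown here, the same group in place of benzamidomethyl gives a 3.6-fold lower number from compound 1 to compound 3 (0.56 log units; beyond the scatter), which shows that a chain with no amide or sulfonyl unit can also lie beyond the scatter from compound 1, so the sulfonyl group of compound 2 is not the only change that separates a compound from compound 1. No measurement shown here explains why such different chains give numbers this close.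

The compounds shown leave open what the bromine and the double bond each contribute, as both arrive together in compound 3. A plain phenyl or a saturated two-carbon link in that chain would separate the two, and an amine or a carboxylic acid on its ring would test a very different kind of end group.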